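Swapping 4-Bromophenyl for 2,6-Dichlorophenyl

The source may report more compounds than this note shows. Statements on the series, on what has been measured and on what is new or still open speak of the compounds shown alone.

In an ADME assay on Vero cells (Chlorocebus sabaeus) for inhibition (on this read-out higher numbers stand for lower toxicity in this test and lower numbers for higher toxicity in this test), compound 1 `COc1ccc(/C=C2\CCC/C(=C\c3ccc(Br)cc3)C2=O)cc1` gives 250000 nM while compound 2 `COc1cccc(/C=C2\CCC/C(=C\c3ccc(Br)cc3)C2=O)c1OC` gives 31500 nM and so holds the lower of the two numbers, by a gap beyond the usual scatter. Compound 2 is therefore the more toxic of the pair in this test.

Compound 3 `COc1cccc(/C=C2\CCC/C(=C\c3c(Cl)cccc3Cl)C2=O)c1OC` carries 2,6-dichlorophenyl in place of 4-bromophenyl on a double-bonded chain carbon bound to a double-bonded ring carbon and otherwise matches compound 2. Within the data shown here, no measured pair shows what this swap does, so the best reference is compound 2 at 31500 nM and no change beyond the scatter is expected. The estimated step is a 1.3-fold higher number from compound 2 to compound 3 (0.10 log units; within the scatter) in this assay and would be a slight move towards lower toxicity, within the scatter. Compound 3 is estimated at 40000 nM (range 12000 nM to 130000 nM).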

Compound 3, half-maximal cytotoxic concentration: 160000 nM
Compound 3: middle estimate off by 4.0-fold (0.60 log units), on the low side; the whole stated range lies below it.
By their numbers in this assay, from the lowest: compound 2; then compounds 3 and 1 (each within the scatter of the next).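

Compounds 1 and 2 both carry 4-bromophenyl, so they said nothing about this position, on a double-bonded chain carbon bound to a double-bonded ring carbon. In this assay, putting 2,6-dichlorophenyl in place of 4-bromophenyl gives a 5.1-fold higher number from compound 2 to compound 3 (0.71 log units; beyond the scatter) and so a move towards lower toxicity in this test, which shows that the group held here can shift the read-out by more than the usual scatter. Nothing available explains why this swap has that effect.

With a single swap at this position, the loss of the bromine and the arrival of the two chlorines cannot be told apart as sources of the step. From the compounds shown here alone, it also remains open how the number would respond to a plain phenyl group here, or to a phenyl ring carrying an amine or a carboxylic acid.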